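Moving one fluorine on the sulfonyl aryl group

The source may hold more compounds than are shown below. What is called first, only, known or untested is meant among the compounds shown, and "the series" means these compounds.

Measured compounds:
- compound 1 `COc1ccc(-c2c(S(=O)(=O)c3cc(F)cc(F)c3)cnc3c(F)cccc23)cc1`: 2.59 mL/min
- compound 2 `O=S(=O)(c1ccc(F)cc1)c1cnc2c(F)cccc2c1-c1cccc(F)c1`: 1.56 mL/min
- compound 3 `O=S(=O)(c1ccc(F)c(F)c1)c1cnc2c(F)cccc2c1-c1cccc(F)c1`: 1.28 mL/min

In an ADME assay on microsomes from liver (Homo sapiens) for metabolic stability, tested at 2.5 uM (a higher number here means faster removal of the compound, a lower number slower removal), compound 3 gives 1.28 mL/min, the lowest of the three numbers, though its gap to compound 2 is within the scatter; only compound 1 sits clearly higher. Compound 4 `O=S(=O)(c1cc(F)cc(F)c1)c1cnc2c(F)cccc2c1-c1cccc(F)c1` differs from compound 3 by 3,5-difluorophenyl in place of 3,4-difluorophenyl on a sulfonyl sulfur. For the measured compounds named here, no measured step mirrors this rearrangement; the only step, a 1.2-fold lower number from compound 2 to compound 3 (0.09 log units; within the scatter), changed nothing beyond the scatter, and compound 1 carries the same 3,5-difluorophenyl but also a different second ring, so it speaks only indirectly. Compound 4 is therefore expected to stay close to compound 3, with a 1.1-fold higher number from compound 3 to compound 4 (0.04 log units; within the scatter) lying within the scatter, so the estimate for compound 4 is 1.4 mL/min, ranging from 0.8 mL/min to 2.6 mL/min.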

Compound 4, intrinsic clearance in a liver preparation (reported as CLH), per the amount of preparation that the assay uses: 1.18 mL/min
For compound 4 the middle estimate is 1.2-fold (0.07 log units) above the measured one; low and high end bracket the measured number.
By their numbers in this assay, from the lowest: compounds 4, 3, 2 and 1 (each within the scatter of the next, the first and the last beyond it).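

In this assay the 3,5-difluorophenyl on the sulfonyl sulfur gives a 1.1-fold lower number from compound 3 to compound 4 (0.04 log units; within the scatter) when it replaces 3,4-difluorophenyl and a 1.3-fold lower number from compound 2 to compound 4 (0.12 log units; within the scatter) when it replaces 4-fluorophenyl, so these three groups cannot be told apart at this position. The step beyond the scatter comes from the other aryl group, where 3-fluorophenyl in place of 4-methoxyphenyl gives a 2.2-fold lower number from compound 1 to compound 4 (0.34 log units; beyond the scatter) and shows that this second place matters more here. Nothing available explains these numbers. Still open, going by these compounds, is whether a quite different group on the sulfonyl sulfur, such as a phenyl ring carrying an amine or a carboxylic acid, would shift the number beyond the scatter.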